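The source may report more compounds than this note shows. Statements on the series, on what has been measured and on what is new or still open speak of the compounds shown alone.

Measured so far:
compound 1, `CN(C)c1nc(N)c2ncn([C@@H]3C[C@@H](O)[C@H](CO)O3)c2n1`; in a functional assay on B-95-8 cells (Cercopithecidae) with B-95-8 cell line (Saguinus oedipus) as the target (a lower number here means a stronger inhibitor, a higher number a weaker inhibitor), compound 1 gives 182 uM
compound 2, `CSc1nc(SC)c2ncn([C@@H]3C[C@@H](O)[C@H](CO)O3)c2n1`; in this assay compound 2 gives 225 uM

Compound 2 holds the higher of the two numbers, but compound 1 lies within the scatter of it, so the two do not separate. Compound 3, `CNc1nc(SC)nc2c1ncn2[C@@H]1C[C@@H](O)[C@H](CO)O1`, differs from compound 2 by methylamino in place of methylsulfanyl on an aromatic carbon. Among the measured compounds shown here, no measured pair shows this change. Compound 1 carries no methylsulfanyl and yet sits within the scatter of compound 2, so in this assay no step beyond the scatter is expected. Compound 3 is estimated at 190 uM, range 80 uM to 450 uM. The expected step is a 1.2-fold lower number from compound 2 to compound 3 (0.07 log units; within the scatter).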

Compound 3, concentration for 50% inhibition: > 300 uM
Compound 3: no number, only a limit; the forecaster's own chance of this, stated with the estimate: 20%; at least 1.5-fold (0.19 log units) between middle value and limit.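

In this assay, methylamino in place of methylsulfanyl on this aromatic carbon, next to the ring nitrogen, gives an at least 1.3-fold higher number from compound 2 to compound 3 (0.12 log units; that floor lies within the scatter). This first one-place pair shows that the change brings no lower number, but the size of the rise cannot be read. The result for compound 3 is a limit and not a number: the limit of > 300 uM in this assay, at which 1 of the 3 values shown sits.

The compounds shown leave open how an ethylamino group, a longer chain or a chlorine on this carbon would read. They also leave open whether any such group would give a number short of the limit.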